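This account rests on a few compounds, and the source may have more. Where it says the series, first, only, none or still open, it means among the compounds named here.

Working notes on the series

The series shares one core, seen in compound 1 `COc1ccc(S(=O)(=O)c2cnc3ccc(F)cc3c2N2CCC(C)CC2)cc1` and compound 2 `CC1CCN(c2c(S(=O)(=O)c3ccc(C#N)cc3)cnc3cc(F)ccc23)CC1`. In an assay on isolated protein for displacement of a labelled ligand from metabotropic glutamate receptor 5 (Homo sapiens), with a stated time of 60 min, tested at 1 uM (a lower number here means less inhibition, a higher number more inhibition at the concentration tested (going by the name of the read-out)), compound 1 gives 85%, and in this assay compound 2 gives 83%. The two numbers lie within the scatter of each other, so compound 2 cannot be set apart from compound 1 on these readings; the two together mark the level at which the series has so far been found.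

The next compound is compound 3 `COc1cccc(S(=O)(=O)c2cnc3cc(F)ccc3c2N2CCC(C)CC2)c1`. It differs from compound 2 in one place: 3-methoxyphenyl in place of 4-cyanophenyl on a sulfonyl sulfur. Compound 1 already carries a methoxyphenyl group on the sulfonyl sulfur and sits at the same level as compound 2, so the exchange of the nitrile-bearing ring for a methoxy-bearing ring is not expected to move the read-out beyond the scatter in either direction.

For compound 3 in this assay an inhibition of 80% is expected, with a range from 60% to 92%. The step of a number 3 percentage points lower from compound 2 to compound 3 (within the scatter) that this estimate means is expected to stay within the scatter.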

Compound 3, a percentage reported as inhibition, at one concentration (the size of the read-out at that concentration, not a potency): 90%
For compound 3 the middle estimate is 10 percentage points below the measured one, and the stated range covers the measured number.
By their numbers in this assay, from the lowest: compounds 2, 1 and 3 (each within the scatter of the next).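

In this assay, going by these compounds alone, 3-methoxyphenyl in place of 4-cyanophenyl on a sulfonyl sulfur gives a number 7 percentage points higher from compound 2 to compound 3 (within the scatter), so this is the first matched pair at this place, and the read-out does not separate the two groups. The place therefore accepts both a nitrile-bearing and a methoxy-bearing phenyl group without a step beyond the scatter, at least for this one pair on the core of compound 2. The exchange alters both the substituent and the number it carries on the ring, as the names 4-cyanophenyl and 3-methoxyphenyl show, and nothing available bears on why the two groups read alike or which of these two differences matters.

Still open, from the compounds shown here alone, is whether the inhibition in this assay stays level with a phenyl ring bearing a carboxylic acid or an amine, or with a short alkyl chain in place of the ring on the sulfonyl sulfur. The read-out is also taken at a single concentration, so any difference in potency between compound 2 and compound 3 that this level of inhibition may hide remains unresolved.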